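A thioether swapped for a benzylamine on the shared core

A few compounds are considered here, and "the series" means these few. Any claim that something is new, unique, unknown or untested is made for them only; others in the source may bear on it.

Compound 2 `Nc1cc(N)c2nc(-c3ccccc3)c(Sc3ccc(F)cc3)nc2c1` carries a (4-fluorophenyl)sulfanyl group on its shared core. In a functional assay on RXF 393 cells (Homo sapiens) for inhibition, read by sulforhodamine B assay, with a stated time of 48 h (a lower number here means a stronger inhibitor of growth, a higher number a weaker inhibitor of growth), compound 2 gives only a limit, < 100000 nM, and no number. Where compound 2 stands is therefore set by the limit of < 100000 nM in this assay, at which 1 of the 2 values shown sits, alone. Compound 1 `CCOC(=O)[C@H](CCC(=O)O)NC(=O)c1ccc(Sc2nc3cc(N)cc(N)c3nc2-c2ccccc2)cc1` bears a different substituent on the same core, and in this assay compound 1 gives 74100 nM. Among the compounds with values here, since one of the two values is a limit, no step between compound 1 and compound 2 can be counted, and the two values show only that both compounds are weak inhibitors of growth in this assay.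

Compound 3 `Nc1cc(N)c2nc(-c3ccccc3)c(NCc3ccc(F)cc3)nc2c1` has not yet been measured. It differs from compound 2 in one place: (4-fluorobenzyl)amino in place of (4-fluorophenyl)sulfanyl on an aromatic carbon. No change of this kind has been measured within the pair, so the data show no direction for it. In this assay the step is expected to be small and of uncertain sign, a step that the limit leaves unreadable from compound 2 to compound 3. Compound 3 is expected to give about 50000 nM in this assay. Compound 3 is estimated to lie between 10000 nM and 100000 nM, with a real chance that only a limit is reported.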

Compound 3, concentration for total growth inhibition: 26900 nM
Estimate against measurement, compound 3: 1.9-fold (0.27 log units) above, within the range that was stated.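

No step from compound 2 to compound 3 can be read in this assay, because compound 2 is known only through a limit: the limit of < 100000 nM in this assay, at which 1 of the 3 values shown sits.

The compounds shown leave open how far, and in which direction, (4-fluorobenzyl)amino in place of (4-fluorophenyl)sulfanyl on the shared core moves the inhibition of growth.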